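A few compounds are considered here, and "the series" means these few. Any claim that something is new, unique, unknown or untested is made for them only; others in the source may bear on it.

In an ADME assay on BHK-21 cells (Mesocricetus auratus) for cytotoxicity, read by MTT assay (a lower number here means that less compound is tolerated, a higher number that more compound is tolerated), compound 2 `C/C(=N\NC(N)=O)c1ccc2[nH]c(-c3ccoc3)nc2c1` gives > 100000 nM, which is a limit of the assay and not a number. Among the compounds with values here, for compound 1 `COc1ccc(-c2nc3cc(/C(C)=N/NC(N)=O)ccc3[nH]2)cc1` the result reads "not determined" (no result reported), so the two compounds offer no measured step to build on. Compound 3 `C/C(=N\NC(N)=O)c1ccc2[nH]c(C3CCCCC3)nc2c1` carries cyclohexyl in place of furan-3-yl on an aromatic carbon, between two ring nitrogen atoms (cyclohexyl in place of furan-3-yl on an aromatic carbon). A modest move towards less compound being tolerated is expected, and the estimated change is an at least 1.4-fold lower number from compound 2 to compound 3 (0.15 log units; that floor lies within the scatter). Compound 3 is expected to read 70000 nM, with an estimated range of 20000 nM to 100000 nM.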

Compound 3, half-maximal cytotoxic concentration: > 100000 nM
Compound 3: a limit, no number; the forecaster's own chance of this, stated with the estimate: 45%; middle value at least 1.4-fold (0.15 log units) away from the limit.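

Compound 2 and compound 3 both end at a limit of the assay in this assay, so no step can be read between them: the limit of > 100000 nM in this assay, at which 2 of the 3 values shown sit. The compounds shown leave open whether cyclohexyl in place of furan-3-yl changes how much compound is tolerated.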